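Methoxy Walk on the Styryl Ring of Benzyl Sulfones

The source may report more compounds than this note shows. Statements on the series, on what has been measured and on what is new or still open speak of the compounds shown alone.

Measured so far:
compound 1, `COc1ccc(/C=C/S(=O)(=O)Cc2ccc(OC)cc2)cc1` — in a functional assay on DU-145 cells (Homo sapiens) for antiproliferative activity, read by trypan blue exclusion (on this read-out lower numbers stand for stronger inhibition and higher numbers for weaker inhibition), compound 1 gives only a limit, > 20000 nM.
compound 2, `COc1ccc(CS(=O)(=O)/C=C/c2ccccc2OC)cc1` — in this assay compound 2 gives 3500 nM.
compound 3, `COc1ccc(CS(=O)(=O)/C=C/c2ccc(OC)c(OC)c2)cc1` — in this assay compound 3 gives only a limit, > 20000 nM.

Compound 1 and compound 2 share the same atoms joined differently; how the two cores differ is not broken down here. Compound 3 arises from compound 1 by methoxy in place of hydrogen on an aromatic carbon; the step is a step that the two limits leave unreadable from compound 1 to compound 3, which cannot be sized because of the limit of > 20000 nM in this assay, at which 2 of the 3 values shown sit.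

Compound 4, `COc1ccc(CS(=O)(=O)/C=C/c2cc(OC)ccc2OC)cc1`, is not yet measured. It arises from compound 2 by methoxy in place of hydrogen on an aromatic carbon. This is the same kind of change as from compound 1 to compound 3, not the same: there the entering group sat ortho to a methoxy group and meta to a large group, here it sits meta to a large group and para to a methoxy group.

Compound 4 is expected to give 6000 nM, with a likely range from 1500 nM to 20000 nM. Relative to compound 2 at 3500 nM, the expected step is a 1.7-fold higher number from compound 2 to compound 4 (0.23 log units; within the scatter), resting only on the one readable value in the set and on the unreadable step that the same kind of change gave before.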

Compound 4, half-maximal inhibitory concentration: > 20000 nM
Compound 4 gave a limit, no number; the forecaster's own chance of this, stated with the estimate: 30%; at least 3.3-fold (0.52 log units) between middle value and limit.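

In this assay, methoxy in place of hydrogen on an aromatic carbon, meta to a large group and para to a methoxy group, gives an at least 5.7-fold higher number from compound 2 to compound 4 (0.75 log units; beyond the scatter). Compound 4 gives only a limit, so this step shows a weaker result on one core alone and does not show how far the loss goes. Whether the change carries over to another core remains unshown, and the step of the same kind on the core of compound 1, made at a different place, cannot be read: the limit of > 20000 nM in this assay, at which 3 of the 4 values shown sit.

The compounds shown leave open whether an amine or a carboxylic acid at this place would retain the result of compound 2, which gives 3500 nM. They also leave open how a longer chain in place of the entering methoxy would read.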